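A few compounds are considered here, and "the series" means these few. Any claim that something is new, unique, unknown or untested is made for them only; others in the source may bear on it.

In an in vitro functional assay on HEK285-7 cells for antagonist activity at prostaglandin D2 receptor 2 (Homo sapiens), read by BRET and beta-arrestin recruitment (a higher number here means a larger maximal response, a lower number a smaller maximal response), compound 1 `O=C(O)Cc1sc(C(c2ccc(F)cc2)c2ccc(F)cc2)nc1-c1ccnc(N2CCC2)c1` gives 80%. Compound 2 `COc1ccc(OC)c(-c2nc(C(c3ccccc3)c3ccccc3)sc2CC(=O)O)c1` gives 80% in this assay, so compound 1 stands level with compound 2, the two values lying within the scatter of each other. Compound 3 `O=C(O)Cc1sc(C(c2ccc(F)cc2)c2ccc(F)cc2)nc1-c1ccnc(Cl)c1` differs from compound 1 in one place: chloro in place of azetidin-1-yl on an aromatic carbon. Among the measured compounds shown here, no step between two measured compounds with this kind of change is available, so the size of the step in this assay can only be guessed; little change beyond the scatter is expected. Compound 3 is expected to give 80%, between 60% and 95%, a step of no change at the digits printed from compound 1 to compound 3 (within the scatter).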

Compound 3, largest response reached (reported as efficacy), in percent of the reference or control that the assay uses: 80%
Compound 3: middle estimate and measured number agree at the digits printed; the measured number falls inside the stated range.
By their numbers in this assay, from the lowest: compounds 1, 2 and 3 (each within the scatter of the next).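

In this assay, putting chloro in place of azetidin-1-yl gives no change at the digits printed from compound 1 to compound 3 (within the scatter) and leaves the fluorinated core otherwise unchanged. Among the compounds shown here, this is the first one-place comparison here, and it shows that on this aromatic carbon next to the ring nitrogen, a single chlorine atom can replace the four-membered ring without a shift beyond the scatter. Nothing available explains this result. As far as these compounds go, whether a methoxy group, a dimethylamino group or a morpholine ring at this position would also fall within the scatter remains open.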